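A few compounds are considered here, and "the series" means these few. Any claim that something is new, unique, unknown or untested is made for them only; others in the source may bear on it.

Compound 1, `Cc1ccccc1-c1ncnc2c1C(=O)N(Cc1cc(C(F)(F)F)cc(C(F)(F)F)c1)C[C@H](C)CO2`, gives 12.6 nM in a functional assay on ileum for antagonist activity at Substance-P receptor (Cavia porcellus); on this read-out higher numbers stand for weaker inhibition and lower numbers for stronger inhibition.
Compound 2, `CC(=O)N1CCN(c2nc3c(c(-c4ccccc4C)n2)C(=O)N(Cc2cc(C(F)(F)F)cc(C(F)(F)F)c2)C[C@H](C)CO3)CC1`, gives 0.139 nM in this assay.
Compound 3, `CC(=O)N1C(C)CN(c2nc3c(c(-c4ccccc4C)n2)C(=O)N(Cc2cc(C(F)(F)F)cc(C(F)(F)F)c2)C[C@H](C)CO3)CC1C`, gives 0.217 nM in this assay.

Among these three numbers compound 3 stands second highest. Its gap to compound 2 is within the usual scatter, so the two cannot be told apart; compound 1 lies far above both, as the step of a 58-fold lower number from compound 1 to compound 3 (1.76 log units; beyond the scatter) shows.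

Compound 4, `CC(=O)N1C(C)CN(c2nc3c(c(-c4ccccc4C)n2)C(=O)N(Cc2cc(C(F)(F)F)cc(C(F)(F)F)c2)CCCO3)CC1C`, differs from compound 3 in a single place: hydrogen in place of methyl on a saturated ring carbon. All measured steps concern a different site, the aromatic carbon of the shared core that carries the six-membered ring with two hetero atoms: a 91-fold lower number from compound 1 to compound 2 (1.96 log units; beyond the scatter), a 58-fold lower number from compound 1 to compound 3 (1.76 log units; beyond the scatter) and a 1.6-fold higher number from compound 2 to compound 3 (0.19 log units; within the scatter). Going by the values given here, none of them changes the eight-membered ring, so no measured step bears directly on the change from compound 3 to compound 4. What remains is the size of the change itself: a single carbon leaves and a hydrogen takes its place, far from the site where large effects were seen. The step is therefore expected to stay within the scatter, or at most to give a modest rise in this assay, as a 1.6-fold higher number from compound 3 to compound 4 (0.21 log units; within the scatter). Compound 4 is estimated at 0.35 nM, within a range from 0.12 nM to 1 nM.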

Compound 4, antagonist equilibrium constant: 0.679 nM
Compound 4: the middle estimate sits 1.9-fold (0.29 log units) below what was measured; measured number inside the range.
By their numbers in this assay, from the lowest: compounds 2 and 3 (each within the scatter of the next); then compound 4; then compound 1.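

In this assay, taking away the methyl on the saturated ring carbon gives a 3.1-fold higher number from compound 3 to compound 4 (0.50 log units; beyond the scatter), a modest step but one beyond the scatter. Going by these compounds alone, this is the first read on the eight-membered ring: all earlier steps lay at the aromatic carbon of the shared core, and they left open whether this ring would respond to any change at all, whereas here the loss of a single carbon is enough to register, with the number rising and inhibition becoming weaker. The step is still much smaller than the large steps seen at that aromatic carbon, and no measurement at hand explains why the methyl matters.

Only methyl and hydrogen are shown on this ring carbon, which leaves open whether a larger ethyl group, a hydroxymethyl group or the methyl in the opposite spatial arrangement would give a lower or a higher number than either. As far as these compounds go, it is also open whether removing the methyl costs the same with the 4-acetylpiperazin-1-yl group of compound 2 on the aromatic carbon, or with the hydrogen of compound 1 there.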